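Swapping the amide aryl group on an aminoquinoline core

This account rests on a few compounds, and the source may have more. Where it says the series, first, only, none or still open, it means among the compounds named here.

Compound 1 `Nc1cccc2c(-c3cccc(NC(=O)c4ccc5c(c4)OCCO5)c3)ccnc12` gives 860 nM in a functional assay on A375P cells (Homo sapiens) for antiproliferative activity, read by MTT assay, with a stated time of 48 h; a lower number here means a stronger inhibitor, a higher number a weaker inhibitor.
Compound 2 `Cc1cc(C(=O)Nc2cccc(-c3ccnc4c(N)cccc34)c2)c(C)o1` gives only a limit, > 20000 nM, in this assay.
Compound 3 `CC(=O)Nc1cccc2c(-c3cccc(NC(=O)c4ccc5c(c4)OCCO5)c3)ccnc12` gives 570 nM in this assay.

Compound 4 `CC(=O)Nc1cccc2c(-c3cccc(NC(=O)c4cc(C)oc4C)c3)ccnc12` has not yet been measured. The cores of compound 1 and compound 3 differ by acetyl in place of hydrogen on a nitrogen on an aromatic ring, and that step was a 1.5-fold lower number from compound 1 to compound 3 (0.18 log units; within the scatter). From compound 1 to compound 2 the change is 2,5-dimethylfuran-3-yl in place of 2,3-dihydro-1,4-benzodioxin-6-yl on a carbonyl carbon, and the step was an at least 23-fold higher number from compound 1 to compound 2 (1.36 log units; beyond the scatter); the value of compound 2 is a limit, as the limit of > 20000 nM in this assay, at which 1 of the 3 values shown sits, records. The same change, (2,5-dimethylfuran-3-yl in place of 2,3-dihydro-1,4-benzodioxin-6-yl on a carbonyl carbon), at the same place, turns compound 3 into compound 4. In this assay the step of a 53-fold higher number from compound 3 to compound 4 (1.72 log units; beyond the scatter) is expected to be large as well, resting on an at least 23-fold higher number from compound 1 to compound 2 (1.36 log units; beyond the scatter) and on (the limit of > 20000 nM in this assay, at which 1 of the 3 values shown sits). Compound 4 is therefore estimated at 30000 nM, expected to lie between 8000 nM and 100000 nM.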

Compound 4, half-maximal inhibitory concentration: > 20000 nM
Compound 4: a limit, no number (the forecaster's own chance of this, stated with the estimate: 75%); the middle value lies beyond the limit too.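

Putting 2,5-dimethylfuran-3-yl in place of 2,3-dihydro-1,4-benzodioxin-6-yl on the carbonyl carbon gives an at least 35-fold higher number from compound 3 to compound 4 (1.54 log units; beyond the scatter) in this assay, so the large step seen on the core of compound 1 appears again on the core of compound 3. The values of compound 2 and compound 4 are both limits, so the step between these two cannot be read. This pair of steps shows the direction carrying over, but not that its size is the same on both cores: the same change on two cores in this assay, an at least 23-fold higher number (1.36 log units; beyond the scatter) from compound 1 to compound 2 and an at least 35-fold higher number (1.54 log units; beyond the scatter) from compound 3 to compound 4; the limit leaves it open whether they differ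

The compounds shown leave open how a plain phenyl or a furan-3-yl without methyl groups would behave on the carbonyl carbon. They also leave open whether a longer chain in place of the acetyl would give a value near that of compound 3.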